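This account rests on a few compounds, and the source may have more. Where it says the series, first, only, none or still open, it means among the compounds named here.

Working notes on the series. The shared core carries a chlorine and a gem-dimethyl lactam joined to a pyridine; the three measured compounds differ only in the substituent on that pyridine. Compound 1 `CCS(=O)(=O)N1CC(Oc2cncc(N3C(=O)c4ccc(Cl)cc4C3(C)C)c2)C1` gives 4 nM in an assay on cells for inhibition of cytochrome P450 11B2, mitochondrial (Homo sapiens), read by HTRF; a higher number here means a weaker inhibitor, a lower number a stronger inhibitor. Compound 2 `CC(=O)NCc1cncc(N2C(=O)c3ccc(Cl)cc3C2(C)C)c1` gives 59 nM in this assay. Compound 3 `CC(=O)N1CCC(c2cncc(N3C(=O)c4ccc(Cl)cc4C3(C)C)c2)CC1` gives 5 nM in this assay. Among the measured compounds shown here, compound 3 and compound 1 sit within the scatter of each other; compound 2 lies beyond the scatter above both, and the single measured step of a 12-fold lower number from compound 2 to compound 3 (1.07 log units; beyond the scatter) shows how much a saturated ring in this position gains over an open acetamidomethyl chain.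

Compound 4 `CC(=O)N1CC[C@H](Oc2cncc(N3C(=O)c4ccc(Cl)cc4C3(C)C)c2)C1` is not yet measured. It differs from compound 3 by a group of 9 heavy atoms (6 carbon, 1 nitrogen, 2 oxygen; one five-membered non-aromatic ring with 1 hetero atom) in place of a group of 9 heavy atoms (7 carbon, 1 nitrogen, 1 oxygen; one six-membered non-aromatic ring with 1 hetero atom), on an aromatic carbon, so a five-membered ring linked through oxygen replaces the six-membered ring linked through carbon. For the measured compounds named here, no measured step bears directly on this exchange; the only step on record, from compound 2 to compound 3, concerns a different kind of change. What can be drawn on is that compound 1, also ether-linked to a small saturated ring, gives 4 nM, within the scatter of compound 3. The expectation for compound 4 is therefore no change at the digits printed from compound 3 to compound 4 (within the scatter), nothing beyond the scatter. Compound 4 is estimated at 5 nM, with a range from 2 nM to 15 nM.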

Compound 4, half-maximal inhibitory concentration: 7 nM
Compound 4: the middle estimate sits 1.4-fold (0.15 log units) below what was measured, and the stated range covers the measured number.
By their numbers in this assay, from the lowest: compounds 1, 3 and 4 (each within the scatter of the next); then compound 2.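

In this assay the five-membered ring linked through oxygen stands in for the 1-acetylpiperidin-4-yl group with a 1.4-fold higher number from compound 3 to compound 4 (0.15 log units; within the scatter), so at this place, two atoms from the ring nitrogen, ring size and linking atom can change together without a shift beyond the scatter. The gain over the open acetamidomethyl chain is not confined to compound 3: an 8.4-fold lower number from compound 2 to compound 4 (0.93 log units; beyond the scatter) is beyond the scatter as well, while a 1.8-fold higher number from compound 1 to compound 4 (0.24 log units; within the scatter) places the two ether-linked compounds within the scatter of each other despite their different rings and ring substituents. No measurement here gives a reason for any of these steps.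

On these data alone, compound 3 and compound 4 differ in ring size and linking atom at once, so the contribution of each on its own remains open, as does the effect of the opposite configuration at the defined stereocentre of compound 4. Also open, as far as these compounds go, is how a free amine or a carboxylic acid in place of the acetyl group on the ring nitrogen would read in this assay.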